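The source may hold more compounds than are shown below. What is called first, only, known or untested is meant among the compounds shown, and "the series" means these compounds.

Measured so far in an ADME assay on HEK293 cells (Homo sapiens) for cytotoxicity, read by MTT assay, with a stated time of 48 h; a lower number here means a stronger inhibitor, a higher number a weaker inhibitor:
compound 1 `COc1ccc(N/C(CCNC2=CC(=O)c3ccccc3C2=O)=N\S(=O)(=O)c2ccc(C)cc2)cc1` gives 35100 nM
compound 2 `Cc1ccc(S(=O)(=O)/N=C(/CCNC2=CC(=O)c3ccccc3C2=O)Nc2ccc(F)cc2)cc1` gives 55100 nM
compound 3 `Cc1ccc(S(=O)(=O)/N=C(/CCNC2=CC(=O)c3ccccc3C2=O)Nc2ccccc2I)cc1` gives 49400 nM

Of the three numbers, that of compound 3 is the second highest, but a 1.1-fold lower number from compound 2 to compound 3 (0.05 log units; within the scatter) and a 1.4-fold higher number from compound 1 to compound 3 (0.15 log units; within the scatter) are both within the scatter, so the three compounds cannot be told apart on these data. Compound 4 `COc1ccc(N/C(CCNC2=CC(=O)c3ccccc3C2=O)=N\S(=O)(=O)c2ccc(C)cc2)cc1OC` differs from compound 3 in one place: 3,4-dimethoxyphenyl in place of 2-iodophenyl on an amine nitrogen. Among the measured compounds shown here, the steps that bear on this are a 1.4-fold higher number from compound 1 to compound 3 (0.15 log units; within the scatter) and a 1.1-fold lower number from compound 2 to compound 3 (0.05 log units; within the scatter), each an exchange of the aryl group on the same nitrogen, and a 1.6-fold higher number from compound 1 to compound 2 (0.20 log units; within the scatter); all three lie within the scatter. Nothing in the series separates one aryl group at that position from another, so no step beyond the scatter is expected in this assay. Compound 4 is therefore expected at 40000 nM, with a range from 20000 nM to 80000 nM. This estimate corresponds to an expected step of a 1.2-fold lower number from compound 3 to compound 4 (0.09 log units; within the scatter).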

Compound 4, half-maximal inhibitory concentration: 60600 nM
Beside the measured number, compound 4's estimate is 1.5-fold (0.18 log units) below it, and the stated range covers the measured number.
By their numbers in this assay, from the lowest: compounds 1, 3, 2 and 4 (each within the scatter of the next).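

In this assay, 3,4-dimethoxyphenyl on the amine nitrogen joins the other aryl groups without separating from them, with a 1.2-fold higher number from compound 3 to compound 4 (0.09 log units; within the scatter) and a 1.1-fold higher number from compound 2 to compound 4 (0.04 log units; within the scatter). Methoxy in place of hydrogen on an aromatic carbon, the smallest change yet at this aryl group, gives a 1.7-fold higher number from compound 1 to compound 4 (0.24 log units; within the scatter), also within the scatter, so two hydrogen-bond acceptors on the ring do not distinguish compound 4 from the halogen-bearing compound 2 and compound 3. No supporting data bear on this result.

From the compounds shown here alone, whether an aryl group carrying a carboxylic acid or an amine, or a plain alkyl chain in place of the aryl group, would give a step beyond the scatter remains open.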